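Replacing Methyl with Methoxy on an Aminochalcone Core

The source may hold more compounds than are shown below. What is called first, only, known or untested is meant among the compounds shown, and "the series" means these compounds.

Compound 1 `C=C(Br)C(=O)Nc1ccc(/C=C/C(=O)c2ccc(C)cc2)cc1` and compound 2 `C=C(Br)C(=O)Nc1ccc(/C=C/C(=O)c2ccc(OC)cc2)cc1` share one core and differ only by methoxy in place of methyl on an aromatic carbon. In an ADME assay on CCRF-CEM cells (Homo sapiens) for antiproliferative activity, with a stated time of 48 h (a lower number here means a stronger inhibitor, a higher number a weaker inhibitor), compound 1 gives 1800 nM, and compound 2 gives 1400 nM; the change made a step of a 1.3-fold lower number from compound 1 to compound 2 (0.11 log units; within the scatter). Compound 3 `Cc1ccc(C(=O)/C=C/c2ccc(N)cc2)cc1` rests on a different core, which differs from the core of compound 1 by hydrogen in place of (1-bromoethenyl)carbonyl on a nitrogen on an aromatic ring. In this assay compound 3 gives 31000 nM, reached through a 17-fold higher number from compound 1 to compound 3 (1.24 log units; beyond the scatter). Compound 4 `COc1ccc(C(=O)/C=C/c2ccc(N)cc2)cc1` is not yet measured. It arises from compound 3 by methoxy in place of methyl on an aromatic carbon, and the surroundings of that place read the same word for word as in the earlier pair, so the change counts as the same. Since the earlier step was a 1.3-fold lower number from compound 1 to compound 2 (0.11 log units; within the scatter), the step from compound 3 to compound 4 is expected to stay within the scatter as well, at a 1.3-fold lower number from compound 3 to compound 4 (0.11 log units; within the scatter). Compound 4 is therefore expected to give about 24000 nM, with a likely span from 12000 nM to 50000 nM.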

Compound 4, half-maximal inhibitory concentration: 37000 nM
Compound 4: the middle estimate sits 1.5-fold (0.19 log units) below what was measured, and the stated range covers the measured number.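

In this assay, methoxy in place of methyl on the core without the (1-bromoethenyl)carbonyl group gave a 1.2-fold higher number from compound 3 to compound 4 (0.08 log units; within the scatter), so this swap made no clear difference on either core, and the two results agree: the same change on two cores in this assay, a 1.3-fold lower number (0.11 log units; within the scatter) from compound 1 to compound 2 and a 1.2-fold higher number (0.08 log units; within the scatter) from compound 3 to compound 4, 1.5-fold (0.19 log units) apart, within the scatter of two such steps.

Hydrogen in place of (1-bromoethenyl)carbonyl on the nitrogen gave a far larger step, a 26-fold higher number from compound 2 to compound 4 (1.42 log units; beyond the scatter), and this large step also carried over between the methyl and methoxy compounds: the same change on two cores in this assay, a 17-fold higher number (1.24 log units; beyond the scatter) from compound 1 to compound 3 and a 26-fold higher number (1.42 log units; beyond the scatter) from compound 2 to compound 4, 1.5-fold (0.19 log units) apart, within the scatter of two such steps.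

For the compounds shown here, these two pairs show only that the swap travelled between these two cores without a visible effect in this one assay; they do not show that methoxy and methyl are interchangeable on other cores, and they do not rule out a small effect hidden within the scatter.

The compounds shown leave open whether a chlorine atom or a longer chain such as ethoxy at the same place would also leave the number unchanged. They also leave open what a plain acetyl group on the nitrogen would give, which would help show how much of the large step depends on the bromine and the carbon-carbon double bond.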